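The source may hold more compounds than are shown below. What is called first, only, known or untested is meant among the compounds shown, and "the series" means these compounds.

Measured in a functional assay on DU-145 cells (Homo sapiens) for cytotoxicity, read by CCK-8 assay and cell counting, with a stated time of 2 days; on this read-out lower numbers stand for stronger inhibition and higher numbers for weaker inhibition:
compound 1, `Oc1ccc(-c2cc(-c3cccs3)nc(-c3ccccc3Cl)c2)cc1`, gives 4190 nM
compound 2, `Oc1cccc(-c2cc(-c3cccs3)nc(-c3ccccc3Cl)c2)c1`, gives 1700 nM
compound 3, `Oc1cccc(-c2cc(-c3ccccc3)nc(-c3ccc(Cl)cc3)c2)c1`, gives 11200 nM

Compound 1 and compound 2 share a core and differ by 4-hydroxyphenyl in place of 3-hydroxyphenyl on an aromatic carbon; this change gave a 2.5-fold higher number from compound 2 to compound 1 (0.39 log units; beyond the scatter). Compound 3 has the highest number of the three; how its core differs from that of compound 2 is not broken down here. Compound 4, `Oc1ccc(-c2cc(-c3ccccc3)nc(-c3ccc(Cl)cc3)c2)cc1`, has not yet been measured; it differs from compound 3 by 4-hydroxyphenyl in place of 3-hydroxyphenyl on an aromatic carbon. This is the same kind of change as from compound 2 to compound 1, though the surroundings differ: here the place is meta to a 4-chlorophenyl group and meta to a phenyl group, whereas before it was meta to a 2-chlorophenyl group and meta to a thiophen-2-yl group. Because the earlier step was a 2.5-fold higher number from compound 2 to compound 1 (0.39 log units; beyond the scatter), a similar step of a 2.3-fold higher number from compound 3 to compound 4 (0.37 log units; beyond the scatter) is expected for compound 4. Compound 4 is therefore estimated at 26000 nM in this assay, within 9000 nM to 75000 nM.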

Compound 4, half-maximal inhibitory concentration: 7270 nM
Beside the measured number, compound 4's estimate is 3.6-fold (0.55 log units) above it, and the stated range ends above it.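

In this assay, 4-hydroxyphenyl in place of 3-hydroxyphenyl gave a 1.5-fold lower number from compound 3 to compound 4 (0.19 log units; within the scatter), so on this core the change shows no effect that stands clear of the usual scatter. The step therefore did not carry over unchanged from one core to the other: the same change on two cores in this assay, a 2.5-fold higher number (0.39 log units; beyond the scatter) from compound 2 to compound 1 and a 1.5-fold lower number (0.19 log units; within the scatter) from compound 3 to compound 4, 3.8-fold (0.58 log units) apart, beyond the scatter of two such steps This does not show which difference between the cores matters, since they differ in both the thiophen-2-yl versus phenyl group and the 2-chlorophenyl versus 4-chlorophenyl group, and two pairs cannot separate these.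

Still open, from the compounds shown here alone, is how the change behaves on a core carrying only one of those two differences. Also open, going by these compounds, is how an amine or a carboxylic acid in place of the hydroxy group would read out in this assay.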